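This account rests on a few compounds, and the source may have more. Where it says the series, first, only, none or still open, it means among the compounds named here.

In a functional assay on the whole organism for inhibition, with Lemna aequinoctialis as the target, with a stated time of 7 days, tested at 500 ug/mL (a lower number here means less inhibition of growth, a higher number more inhibition of growth at the concentration tested), two compounds built on a shared core have been measured. Compound 1 (`O=C1Nc2ccc(F)cc2/C1=N/NC(=S)Nc1ccccc1C(F)(F)F`) gives 25%, and compound 2 (`O=C1Nc2ccc(F)cc2/C1=N/NC(=S)Nc1ccc(C(F)(F)F)cc1`) gives 25%, so compound 2 stands level with compound 1, within the scatter. The compound still unmeasured is compound 3 (`O=C1Nc2ccc(F)cc2/C1=N/NC(=S)Nc1ccc(F)cc1`). It carries fluoro in place of trifluoromethyl on an aromatic carbon of compound 2: fluoro in place of trifluoromethyl on an aromatic carbon. Among the measured compounds shown here, no measured pair shows what this exchange does in this assay, so the data offer no direct guide. The expectation rests only on compound 1 at 25% and compound 2 at 25%, and it is for no step beyond the scatter, in neither direction. The estimated change is a number 2 percentage points higher from compound 2 to compound 3 (within the scatter). For compound 3 the expected growth inhibition is 27%, with an estimated range of 12% to 45%.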

Compound 3, percent growth inhibition at one concentration: 35%
Beside the measured number, compound 3's estimate is 8 percentage points below it; measured number inside the range.
By their numbers in this assay, from the lowest: compounds 1, 2 and 3 (each within the scatter of the next).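

In this assay, the exchange of trifluoromethyl for fluoro now has its first measured pair: a number 10 percentage points higher from compound 2 to compound 3 (within the scatter). On this aromatic carbon, para to a large group, a single fluorine and the four-atom trifluoromethyl therefore give growth inhibition that cannot be told apart at the concentration tested, so this one exchange shows no step beyond the scatter. Nothing measured here bears on what lies behind this reading.

On these data alone, whether an amine, a carboxylic acid or a methoxy group on the same carbon would give a step beyond the scatter remains open. So does the effect of fluoro in place of the trifluoromethyl of compound 1, and with only one concentration shown, any difference at other concentrations also remains unknown.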